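The source may report more compounds than this note shows. Statements on the series, on what has been measured and on what is new or still open speak of the compounds shown alone.

Measured so far in an ADME assay on the whole organism for pharmacokinetics, with Rattus norvegicus as the target; a higher number here means that more of the compound sits outside the plasma, a lower number that more of the compound stays in the plasma:
- compound 1 `COc1cc2nnc(C(N)=O)c(Nc3ccc(C)cc3F)c2cc1N1CCC(OC)CC1`: 1.8 L/kg
- compound 2 `COc1cc2nnc(C(N)=O)c(Nc3ccc(C)cc3F)c2cc1N1CCN(S(C)(=O)=O)CC1`: 1.7 L/kg
- compound 3 `COc1cc2nnc(C(N)=O)c(Nc3ccc(C)cc3F)c2cc1N1C[C@@H](C)N[C@@H](C)C1`: 1.6 L/kg

Compound 2, which carries the 4-(methylsulfonyl)piperazin-1-yl group, does not stand apart from the other two. The comparison with its neighbours gives a 1.1-fold lower number from compound 1 to compound 2 (0.02 log units; within the scatter) and a 1.1-fold lower number from compound 2 to compound 3 (0.03 log units; within the scatter). Next comes compound 4 `COc1cc2nnc(C(N)=O)c(Nc3ccc(C)cc3F)c2cc1N1CCN(C)CC1`, which has not yet been measured. It has methyl in place of methylsulfonyl on an amine nitrogen in a ring. Among the compounds with values here, no measured pair makes exactly this change, so the evidence is indirect. It comes from the swaps of the whole group on the shared core, the two above and a 1.1-fold lower number from compound 1 to compound 3 (0.05 log units; within the scatter). All three stayed within the scatter in this assay, which gives no reason to expect a shift in either direction. Three compounds are a thin basis, however, and none of them has a methyl on that nitrogen. The expected change, within the scatter, is a 1.1-fold higher number from compound 2 to compound 4 (0.02 log units; within the scatter). Compound 4 is estimated at 1.8 L/kg, with an expected range from 1 L/kg to 3.2 L/kg.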

Compound 4, volume of distribution at steady state: 3.8 L/kg
For compound 4 the middle estimate is 2.1-fold (0.32 log units) below the measured one; measured number above the stated range.
By their numbers in this assay, from the lowest: compounds 3, 2 and 1 (each within the scatter of the next); then compound 4.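

In this assay the substituent on this amine nitrogen does matter: methyl in place of methylsulfonyl gives a 2.2-fold higher number from compound 2 to compound 4 (0.35 log units; beyond the scatter) and is the first step among these compounds to lie beyond the scatter. The 4-methylpiperazin-1-yl group also stands apart from the other two groups on the shared core, with a 2.4-fold higher number from compound 3 to compound 4 (0.38 log units; beyond the scatter) and with a 2.1-fold higher number from compound 1 to compound 4 (0.32 log units; beyond the scatter) while the three earlier compounds stay within the scatter of one another. No measured evidence is available here to explain these steps.

The compounds shown leave open whether this higher number belongs to methyl alone or would also appear with ethyl, a longer chain or an acetyl group on the same nitrogen. They also leave open whether the same change would give a similar step on a different core.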